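A few compounds are considered here, and "the series" means these few. Any claim that something is new, unique, unknown or untested is made for them only; others in the source may bear on it.

Compound 1 `Nc1nc(N)c(-c2ccc(NCc3ccc([N+](=O)[O-])cc3)cc2)c(COCc2ccccc2)n1`: 0.2 nM
Compound 2 `Nc1nc(N)c(-c2ccc(NCc3ccnc(Cl)c3)cc2)c(COCc2ccccc2)n1`: 1.5 nM

Among the compounds with values here, in an in vitro assay on CHOK cells for displacement of a labelled ligand from growth hormone secretagogue receptor type 1 (Homo sapiens) (on this read-out higher numbers stand for weaker inhibition and lower numbers for stronger inhibition), compound 2 gives 1.5 nM, the highest of the two numbers so far; the single measured step, a 7.5-fold higher number from compound 1 to compound 2 (0.88 log units; beyond the scatter), separates it from compound 1. Compound 3 `N#Cc1ccc(CNc2ccc(-c3c(N)nc(N)nc3COCc3ccccc3)cc2)cc1` differs from compound 2 by 4-cyanophenyl in place of 2-chloropyridin-4-yl on a saturated chain carbon bound to a nitrogen on an aromatic ring. Within the data shown here, only that one step bears on this change: it exchanged a carbon-only six-membered ring for the 2-chloropyridin-4-yl ring and raised the number. Compound 3 returns to a carbon-only six-membered ring, so a step back toward compound 1 is expected, with the 4-nitrophenyl to 4-cyanophenyl difference leaving room for uncertainty. Compound 3 is estimated at 0.4 nM (range 0.15 nM to 1.2 nM), an expected step of a 3.8-fold lower number from compound 2 to compound 3 (0.57 log units; beyond the scatter).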

Compound 3, half-maximal inhibitory concentration: 2.8 nM
The estimate for compound 3 lay 7.0-fold (0.85 log units) below the measured number; measured number outside the range, above it.
By their numbers in this assay, from the lowest: compound 1; then compounds 2 and 3 (each within the scatter of the next).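

In this assay, a carbon-only ring at this place does not by itself bring the number back toward compound 1: the change shows a 1.9-fold higher number from compound 2 to compound 3 (0.27 log units; within the scatter) and so does not separate 4-cyanophenyl from 2-chloropyridin-4-yl. The sharper dependence lies in the group on the ring, since cyano in place of nitro on an aromatic carbon gives a 14-fold higher number from compound 1 to compound 3 (1.15 log units; beyond the scatter) and leaves compound 1 apart from compound 2 and compound 3. No evidence is available that explains these differences. Still open, as far as these compounds go, is whether nitro is unique here, or whether a carboxylic acid, methyl ester or sulfonamide on the same ring could match compound 1.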